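Changing the group on the amine nitrogen

This account rests on a few compounds, and the source may have more. Where it says the series, first, only, none or still open, it means among the compounds named here.

In a functional assay on MGC-803 cells (Homo sapiens) for inhibition, read by sulforhodamine B assay (a higher number here means a weaker inhibitor, a lower number a stronger inhibitor), compound 1 `O=C1C=C(NCc2ccccc2)C(=O)c2c1nc1n2[C@H]2OC[C@@H](O)[C@H]2OC1` gives 2670 nM and compound 3 `O=C1C=C(Nc2cccc(F)c2)C(=O)c2c1nc1n2[C@H]2OC[C@@H](O)[C@H]2OC1` gives 2180 nM, two values within the scatter of each other. Compound 2 `O=C1C=C(N2CCC2)C(=O)c2c1nc1n2[C@H]2OC[C@@H](O)[C@H]2OC1` gives only a limit, > 16000 nM. Compound 4 `COc1ccccc1NC1=CC(=O)c2nc3n(c2C1=O)[C@H]1OC[C@@H](O)[C@H]1OC3` has 2-methoxyphenyl in place of 3-fluorophenyl on an amine nitrogen. Replacing azetidin-1-yl with (3-fluorophenyl)amino gave an at least 7.3-fold lower number from compound 2 to compound 3 (0.86 log units; beyond the scatter), but that step changes more than the present one. Exchanging benzyl for 3-fluorophenyl on the amine nitrogen gave a 1.2-fold lower number from compound 1 to compound 3 (0.09 log units; within the scatter), which lies within the scatter. That exchange is the closest guide, so no step beyond the scatter is expected here. The estimated step is a 1.1-fold higher number from compound 3 to compound 4 (0.06 log units; within the scatter). For compound 4, the expected value is 2500 nM, with an estimated range of 1000 nM to 6500 nM.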

Compound 4, half-maximal inhibitory concentration: 1630 nM
Beside the measured number, compound 4's estimate is 1.5-fold (0.19 log units) above it; the range from low to high includes it.
By their numbers in this assay, from the lowest: compounds 4, 3 and 1 (each within the scatter of the next). At a limit, above all of these: compound 2.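

In this assay, 2-methoxyphenyl in place of 3-fluorophenyl gives a 1.3-fold lower number from compound 3 to compound 4 (0.13 log units; within the scatter), and in place of benzyl it gives a 1.6-fold lower number from compound 1 to compound 4 (0.21 log units; within the scatter). On this amine nitrogen, then, a group with a hydrogen-bond acceptor, which 3-fluorophenyl and benzyl lack, produces no step beyond the scatter. (2-Methoxyphenyl)amino in place of azetidin-1-yl gives an at least 9.8-fold lower number from compound 2 to compound 4 (0.99 log units; beyond the scatter), but compound 2 has only a limit, so this size is a bound: the limit of > 16000 nM in this assay, at which 1 of the 4 values shown sits.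

Still open, going by these compounds, is how an unsubstituted phenyl or a phenyl bearing a carboxylic acid would compare on this nitrogen. A morpholin-4-yl group could also test whether azetidin-1-yl is an isolated case.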